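The source may report more compounds than this note shows. Statements on the series, on what has been measured and on what is new or still open speak of the compounds shown alone.

Compound 1 `CC1CCC(C(C)C)C(O[C@H]2OC(=O)C(Br)=C2Sc2nnc(-c3cccnc3)s2)C1`: in a functional assay on HeLa cells (Homo sapiens) for antiproliferative activity, read by MTT assay, with a stated time of 24 h (on this read-out lower numbers stand for stronger inhibition and higher numbers for weaker inhibition), compound 1 gives 5600 nM.
Compound 2 `CC1(C)C2CCC1(C)C(O[C@H]1OC(=O)C(Br)=C1Sc1nnc(-c3ccncc3)s1)C2`: in this assay compound 2 gives 3000 nM.

Compound 2 has the lower of these two numbers, but its gap to compound 1 lies within the usual scatter, so neither compound can be called the stronger one. Compound 3 `CC1(C)C2CCC1(C)C(O[C@H]1OC(=O)C(Br)=C1Sc1nnc(-c3cccnc3)s1)C2` keeps the core of compound 2 and carries pyridin-3-yl in place of pyridin-4-yl on an aromatic carbon. Going by the values given here, no measured pair isolates this swap, so the expected step in this assay is none beyond the scatter, in either direction. Compound 3 is therefore estimated at 4000 nM, with a range from 1500 nM to 11000 nM. The step this expectation means is a 1.3-fold higher number from compound 2 to compound 3 (0.12 log units; within the scatter).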

Compound 3, half-maximal inhibitory concentration: 3400 nM
For compound 3 the middle estimate is 1.2-fold (0.07 log units) above the measured one, and the stated range covers the measured number.
By their numbers in this assay, from the lowest: compounds 2, 3 and 1 (each within the scatter of the next).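

In this assay, pyridin-3-yl in place of pyridin-4-yl gives a 1.1-fold higher number from compound 2 to compound 3 (0.05 log units; within the scatter) and so, on this core, the swap makes no readable difference. Compounds 1 and 3 share pyridin-3-yl and differ only in the group on the oxygen, where the change gives a 1.6-fold lower number from compound 1 to compound 3 (0.22 log units; within the scatter) and likewise cannot be read as a gain or a loss. No further measurement bears on these results. From the compounds shown here alone, whether a plain phenyl ring in that place, or an amine on the pyridine ring, would give a step beyond the scatter remains open.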